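A few compounds are considered here, and "the series" means these few. Any claim that something is new, unique, unknown or untested is made for them only; others in the source may bear on it.

In a functional assay on MCF7 cells (Homo sapiens) for antiproliferative activity, read by CellTiter-Glo, with a stated time of 5 days (on this read-out higher numbers stand for weaker inhibition and lower numbers for stronger inhibition), compound 1 (`CC/C(=C(/c1ccc(/C=C/C(=O)O)cc1)c1ccc2nccn2c1)c1ccccc1`) gives 170 nM as its value. Compound 2 (`CC/C(=C(/c1ccc(/C=C/C(=O)O)cc1)c1ccc2ncsc2c1)c1ccccc1`) stands at > 500 nM which is a limit and not a number. For the measured compounds named here, the one measured step is an at least 2.9-fold higher number from compound 1 to compound 2 (0.46 log units; beyond the scatter) and it comes from exchanging the whole ring group on the double-bonded chain carbon. Compound 3 (`CC/C(=C(/c1ccc(/C=C/C(=O)O)cc1)c1ccc2sncc2c1)c1ccccc1`) differs from compound 2 by a group of 9 heavy atoms (7 carbon, 1 nitrogen, 1 sulfur; one five-membered aromatic ring with 2 hetero atoms, one six-membered aromatic ring of carbon only) in place of a group of 9 heavy atoms (7 carbon, 1 nitrogen, 1 sulfur; one five-membered aromatic ring with 2 hetero atoms, one six-membered aromatic ring of carbon only), on a double-bonded chain carbon bound to an aromatic carbon and a double-bonded chain carbon with the same atoms joined differently and 1,3-benzothiazol-6-yl leaving. Going by the values given here, no measured step covers such a rearrangement, so no change beyond the scatter is expected. The expected step in this assay is a number no higher from compound 2 to compound 3 (the limit leaves the size open) in this estimate. Compound 3 is expected near 500 nM with an estimated range from 170 nM to 1500 nM as its likely span.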

Compound 3, half-maximal inhibitory concentration: > 500 nM
Compound 3: only a limit was reported (the forecaster's own chance of this, stated with the estimate: 50%); the middle value lies on the limit itself.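

In this assay, compound 3 is reported only as a limit, not a number. Joining the same ring atoms differently, with 1,3-benzothiazol-6-yl leaving, has an effect that cannot be read, because compound 2 and compound 3 both stop at a limit: the limit of > 500 nM in this assay, at which 2 of the 3 values shown sit. The one readable change is an at least 2.9-fold higher number from compound 1 to compound 3 (0.46 log units; beyond the scatter), so a second group with a six-membered ring of carbon only also gives weaker inhibition at this place.

On these data alone, how far compound 2 and compound 3 lie past the limit stays open. So does whether a ring group carrying an amine would bring the number back towards that of compound 1, 170 nM.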